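Chloro addition on the furan analogue of the nitrostyryl ketone series

The source may report more compounds than this note shows. Statements on the series, on what has been measured and on what is new or still open speak of the compounds shown alone.

Three compounds of this series carry a measurement. Compound 1 `O=C(/C=C/c1cccc([N+](=O)[O-])c1)c1ccc[nH]1` in a functional assay on MOLT-4 cells (Homo sapiens) for inhibition, read by MTT assay, with a stated time of 48 h (a higher number here means a weaker inhibitor, a lower number a stronger inhibitor), gives 22000 nM. Compound 2 `O=C(/C=C/c1cc([N+](=O)[O-])ccc1Cl)c1ccc[nH]1` in this assay gives 42000 nM. Compound 3 `O=C(/C=C/c1cccc([N+](=O)[O-])c1)c1ccco1` in this assay gives 18000 nM. The difference between compound 1 and compound 2 is chloro in place of hydrogen on an aromatic carbon, and the step it made was a 1.9-fold higher number from compound 1 to compound 2 (0.28 log units; within the scatter). The two cores differ by furan-2-yl in place of 1H-pyrrol-2-yl on a carbonyl carbon, with a step of a 1.2-fold lower number from compound 1 to compound 3 (0.09 log units; within the scatter). Compound 3 carries the lowest of the three numbers, but its gap to compound 1 is within the scatter, so no order between those two is claimed; only the gap to compound 2 is beyond the scatter.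

Compound 4 `O=C(/C=C/c1cc([N+](=O)[O-])ccc1Cl)c1ccco1` has not been measured. It differs from compound 3 by chloro in place of hydrogen on an aromatic carbon. The place of the change is the same as in the pair of compound 1 and compound 2, so this is the same change made a second time, now on the furan core instead of the pyrrole core. The change occurs twice among the compounds shown.

In this assay, among the compounds with values here, the expected step is a 1.9-fold higher number from compound 3 to compound 4 (0.28 log units; within the scatter), because a 1.9-fold higher number from compound 1 to compound 2 (0.28 log units; within the scatter) is the one measured instance of this change and nothing in the data suggests the core alters it. For compound 4 the estimate in this assay is 34000 nM, with a likely range from 17000 nM to 70000 nM. The range is wide since a single measured step underpins it.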

Compound 4, half-maximal inhibitory concentration: 72000 nM
Beside the measured number, compound 4's estimate is 2.1-fold (0.33 log units) below it, and the stated range ends below it.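

In this assay the chloro change on the core of compound 3 gave a 4.0-fold higher number from compound 3 to compound 4 (0.60 log units; beyond the scatter), a step beyond the scatter, and set beside its earlier instance it cannot be told apart from that instance: the same change on two cores in this assay, a 1.9-fold higher number (0.28 log units; within the scatter) from compound 1 to compound 2 and a 4.0-fold higher number (0.60 log units; beyond the scatter) from compound 3 to compound 4, 2.1-fold (0.32 log units) apart, within the scatter of two such steps. The exchange of cores with chloro in place gave a 1.7-fold higher number from compound 2 to compound 4 (0.23 log units; within the scatter), which is within the scatter and likewise cannot be told apart from the same exchange without chloro: the same change on two cores in this assay, a 1.2-fold lower number (0.09 log units; within the scatter) from compound 1 to compound 3 and a 1.7-fold higher number (0.23 log units; within the scatter) from compound 2 to compound 4, 2.1-fold (0.32 log units) apart, within the scatter of two such steps. The four compounds therefore show no sign that the core alters the chloro step, and carrying the step across the two cores is compatible with the data, but with one pair per core they do not show that the step is the same size on both, nor that it holds on any other core.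

The compounds shown leave open whether the larger step on the core of compound 3 would hold up on repeat measurement, and whether a third core would give a step of similar size. They also leave open how an amine, a carboxylic acid or a longer chain would behave at the aromatic carbon that carries chloro, para to the nitro group.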